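Swapping the chain-end amine of compound 3

The source may hold more compounds than are shown below. What is called first, only, known or untested is meant among the compounds shown, and "the series" means these compounds.

Measured in a functional assay on HCT-116 cells (Homo sapiens) for cytotoxicity, read by MTT assay, with a stated time of 72 h (a higher number here means a weaker inhibitor, a lower number a stronger inhibitor), so far:
Compound 1 `O=C1c2c[n+]([O-])c3ccccc3c2C(=O)c2c1c1ccccc1n2Cc1cn([C@@H]2C[C@H](O)[C@@H](CO)O2)nn1` gives 50 nM here
Compound 2 `O=C1c2c[n+]([O-])c3ccccc3c2C(=O)c2c1c1ccccc1n2Cc1cn(CC(O)CO)nn1` gives 250 nM here
Compound 3 `O=C1c2c[n+]([O-])c3ccccc3c2C(=O)c2c1c1ccccc1n2CCN1CCCC1` gives 270 nM here

Compound 3 (270 nM) cannot be told apart from compound 2 within the scatter, while its number stands beyond the scatter above that of compound 1. The next compound to be measured is compound 4 `CCCN1CCN(CCCCn2c3c(c4ccccc42)C(=O)c2c[n+]([O-])c4ccccc4c2C3=O)CC1` in the same test. The change 2-(4-propylpiperazin-1-yl)ethyl in place of pyrrolidin-1-yl on a saturated chain carbon, two bonds along the chain from an aromatic nitrogen puts 2-(4-propylpiperazin-1-yl)ethyl in place of pyrrolidin-1-yl on a saturated chain carbon, two bonds along the chain from an aromatic nitrogen.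

Among the measured compounds shown here, two measured steps bear on this, and neither is the same change, so the evidence is indirect. The closer one, a 1.1-fold higher number from compound 2 to compound 3 (0.03 log units; within the scatter), replaced the group on this same chain and stayed within the scatter. The other, a 5.0-fold higher number from compound 1 to compound 2 (0.70 log units; beyond the scatter), is modest and lies beyond the scatter, but it concerns a substituent on an aromatic nitrogen. From the first of these, no step beyond the scatter is expected in this assay and no direction is favoured, although a modest step cannot be ruled out. The expected step is a 1.1-fold lower number from compound 3 to compound 4 (0.03 log units; within the scatter) on this estimate. For compound 4 the estimated value is 250 nM with 90 nM to 700 nM as the expected range.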

Compound 4, half-maximal inhibitory concentration: 790 nM
Beside the measured number, compound 4's estimate is 3.2-fold (0.50 log units) below it, and the stated range ends below it.
By their numbers in this assay, from the lowest: compound 1; then compounds 2 and 3 (each within the scatter of the next); then compound 4.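

In this assay, among the compounds shown here, this position proves sensitive to what stands at the chain end: replacing pyrrolidin-1-yl with 2-(4-propylpiperazin-1-yl)ethyl gives a 2.9-fold higher number from compound 3 to compound 4 (0.47 log units; beyond the scatter), the first step beyond the scatter among changes made on this chain, whereas the earlier one gave a 1.1-fold higher number from compound 2 to compound 3 (0.03 log units; within the scatter). The triazole-bearing comparison points the same way, with a 3.2-fold higher number from compound 2 to compound 4 (0.50 log units; beyond the scatter), so compound 4 stands apart from both earlier compounds with this chain position changed, although both new steps are only modest. Nothing available here accounts for this loss of cytotoxic strength.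

The change from (pyrrolidin-1-yl)methyl to 3-(4-propylpiperazin-1-yl)propyl alters the ring, its propyl group and the length of the chain together, so the compounds shown cannot assign the step to any one of these. A 4-propylpiperazin-1-yl group in the exact place of pyrrolidin-1-yl would separate the ring from the chain length, and a morpholin-4-yl or piperidin-1-yl group there would show whether other ring amines follow compound 3 or compound 4.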